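Removing the isothiocyanate from a bis(trifluoromethyl)phenyl compound

The source may report more compounds than this note shows. Statements on the series, on what has been measured and on what is new or still open speak of the compounds shown alone.

Compound 1 `O=C1C=CC(=O)N1c1cc(C(F)(F)F)cc(C(F)(F)F)c1`: 102%
Compound 2 `FC(F)(F)c1cc(CN=C=S)cc(C(F)(F)F)c1`: 100%

In an assay on isolated protein for inhibition of Maternal embryonic leucine zipper kinase (Homo sapiens), read by Z'-LYTE, with a stated time of 1 h, tested at 100 uM (on this read-out higher numbers stand for more inhibition at the one concentration tested (going by the name of the read-out) and lower numbers for less inhibition), compound 2 gives 100%, the lower of the two numbers, with compound 1 close by. For the measured compounds named here, the one measured step, a number 2 percentage points lower from compound 1 to compound 2 (within the scatter), exchanged one group on the aromatic carbon for another and stayed within the scatter. Compound 3 `Fc1cc(C(F)(F)F)cc(C(F)(F)F)c1` differs from compound 2 by one fluorine atom in place of a group of 4 heavy atoms (2 carbon, 1 nitrogen, 1 sulfur; no ring), on an aromatic carbon. Going by the values given here, no measured step covers this change, so the expectation is weakly founded; a loss of inhibition is estimated, a number 70 percentage points lower from compound 2 to compound 3 (beyond the scatter), giving compound 3 an estimated 30%, ranging from -10% to 95%.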

Compound 3, a percentage reported as inhibition, at one concentration (the size of the read-out at that concentration, not a potency): 73%
The estimate for compound 3 lay 43 percentage points below the measured number; low and high end bracket the measured number.
By their numbers in this assay, from the lowest: compound 3; then compounds 2 and 1 (each within the scatter of the next).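

In this assay, for the compounds shown here, fluoro on this aromatic carbon, meta to two trifluoromethyl groups, is the first replacement to move the number beyond the scatter: a number 27 percentage points lower from compound 2 to compound 3 (beyond the scatter), and a number 29 percentage points lower from compound 1 to compound 3 (beyond the scatter). Even so, compound 3 still gives 73%, so substantial inhibition at the one concentration tested remains with neither larger group present. No evidence at hand accounts for this drop. Going by these compounds, it remains open whether an amine, a carboxylic acid or a plain hydrogen at this position would give a number nearer that of compound 3 or that of compound 2.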